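Compound 2 and its mirror image, compound 3

The source may hold more compounds than are shown below. What is called first, only, known or untested is meant among the compounds shown, and "the series" means these compounds.

In a functional assay on A549 cells (Homo sapiens) for cytotoxicity, read by MTT assay, with a stated time of 48 h (a higher number here means a weaker inhibitor, a lower number a stronger inhibitor), compound 1 (`CCOC(=O)[C@@]1(C(=O)NCc2ccc(C)cc2)C[C@H]1c1cc(OC)c(OC)c(OC)c1`) gives 17100 nM, and compound 2 (`CCOC(=O)[C@]1(C(=O)Nc2ccccc2Cl)C[C@@H]1c1cc(OC)c(OC)c(OC)c1`) gives 50900 nM. Compound 2 therefore has the higher of the two numbers, and the gap lies beyond the scatter, making it the weaker inhibitor of the pair.

The next entry is compound 3 (`CCOC(=O)[C@@]1(C(=O)Nc2ccccc2Cl)C[C@H]1c1cc(OC)c(OC)c(OC)c1`). Relative to compound 2, the change is the two compounds have the same atoms and bonds and differ only in configuration as drawn: 2 of 2 stereo elements differ (all stereocentres are inverted: mirror images); a stereocentre at a saturated ring carbon is drawn R in compound 2 and S in compound 3; a stereocentre at a saturated ring carbon is drawn R in compound 2 and S in compound 3. Within the data shown here, no measured pair isolates a change of configuration, so the data give no direct guide to the size of this step. In this assay, no step beyond the scatter is expected, with only a slight lean towards a lower number. The expected change is a 1.3-fold lower number from compound 2 to compound 3 (0.13 log units; within the scatter). For compound 3, the estimated value is 38000 nM, with an expected range of 12000 nM to 100000 nM.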

Compound 3, half-maximal inhibitory concentration: 17600 nM
Estimate against measurement, compound 3: 2.2-fold (0.33 log units) above; the measured number falls inside the stated range.
By their numbers in this assay, from the lowest: compounds 1 and 3 (each within the scatter of the next); then compound 2.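

Inverting both stereocentres of the 2-chlorophenyl amide gives a 2.9-fold lower number from compound 2 to compound 3 (0.46 log units; beyond the scatter) in this assay and is the first step in the series to isolate configuration. With the configuration of compound 3, 2-chlorophenyl in place of 4-methylbenzyl on an amide-type nitrogen gives a 1.0-fold higher number from compound 1 to compound 3 (0.01 log units; within the scatter), so this amide change leaves the number within the scatter. The gap between the mirror images can be assigned to configuration as drawn, because nothing else separates them: the fact that compounds 2 and 3 differ only in the configuration as drawn

Going by these compounds, whether the same inversion shifts the number to a similar extent when 4-methylbenzyl sits on the amide nitrogen remains open. Also open, on these data alone, is how a carboxylic acid in place of the ethyl ester, or an amine on the amide substituent, would behave in either configuration.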